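The source may report more compounds than this note shows. Statements on the series, on what has been measured and on what is new or still open speak of the compounds shown alone.

The measured compounds:
- compound 1 `COc1cc(C=C2C(=O)N(c3ccc(Cl)cc3)N(c3ccc(Cl)cc3)C2=O)cc(OC)c1OC`: 16200 nM in a functional assay on MCF7 cells (Homo sapiens) for cytotoxicity, read by MTT assay, with a stated time of 72 h; a higher number here means a weaker inhibitor, a lower number a stronger inhibitor
- compound 2 `COc1ccc(C=C2C(=O)N(c3ccc(Cl)cc3)N(c3ccc(Cl)cc3)C2=O)cc1`: > 128000 nM, which is a limit of the assay and not a number
- compound 3 `O=C1C(=Cc2ccco2)C(=O)N(c2ccc(Cl)cc2)N1c1ccc(Cl)cc1`: 20300 nM

Within the data shown here, compound 2 is the one compound for which only a limit is known; its result sits at the limit of > 128000 nM in this assay, at which 1 of the 3 values shown sits, so its true potency is not pinned down. The step to compound 4 `O=C1C(=Cc2c[nH]c3ccccc23)C(=O)N(c2ccc(Cl)cc2)N1c1ccc(Cl)cc1` changes a single group: 1H-indol-3-yl in place of 4-methoxyphenyl on a double-bonded chain carbon bound to a double-bonded ring carbon. Among the measured compounds shown here, one measured step touches the same place, and it was an at least 6.3-fold lower number from compound 2 to compound 3 (0.79 log units; beyond the scatter), which took the result from a limit to a number. For the measured compounds named here, compound 1, which also carries a different group at that place, gives a number, 16200 nM, though no single-change step links it to compound 2. Together these show that swapping out 4-methoxyphenyl at this place has, where measured, moved the number down beyond the scatter. A similar lowering is expected for compound 4, an at least 5.1-fold lower number from compound 2 to compound 4 (0.70 log units; beyond the scatter), landing it in the same region as compounds 1 and 3. Since the starting point is only a limit, the size of the step is uncertain. The estimate for compound 4 is 25000 nM, expected to fall between 8000 nM and 100000 nM.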

Compound 4, half-maximal inhibitory concentration: 34200 nM
For compound 4 the middle estimate is 1.4-fold (0.14 log units) below the measured one; measured number inside the range.
By their numbers in this assay, from the lowest: compounds 1, 3 and 4 (each within the scatter of the next, the first and the last beyond it). At a limit, above all of these: compound 2.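

In this assay, a second replacement of 4-methoxyphenyl on a double-bonded chain carbon bound to a double-bonded ring carbon gave an at least 3.7-fold lower number from compound 2 to compound 4 (0.57 log units; beyond the scatter), so the lowering seen with furan-2-yl is not tied to that one group. Exchanging one replacement for the other gave a 1.7-fold higher number from compound 3 to compound 4 (0.23 log units; within the scatter), so although 1H-indol-3-yl adds a hydrogen-bond donor, this assay does not tell it apart from furan-2-yl. The true size of the step away from 4-methoxyphenyl stays unknown, because compound 2 gives only a limit and not a number: the limit of > 128000 nM in this assay, at which 1 of the 4 values shown sits.

As far as these compounds go, the groups compared here at this place are all aromatic, so it remains open whether a carboxylic acid or an amine on a short open chain would give a number in the same region or a different one. From the compounds shown here alone, it is also open whether the hydrogen on the nitrogen of 1H-indol-3-yl plays any part, which a methyl group on that nitrogen would test, and whether any group at this place can take the number well below those of compounds 1, 3 and 4.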